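Naphthalen-1-yl in Place of Phenyl on the Ketone

The source may hold more compounds than are shown below. What is called first, only, known or untested is meant among the compounds shown, and "the series" means these compounds.

Compound 1 `COc1cc(-c2nnc3n2NC(c2ccco2)C(C(=O)c2ccc(Br)cc2)S3)cc(OC)c1OC` gives > 100000 nM in a functional assay on HepG2 cells (Homo sapiens) for cytotoxicity, read by MTT assay, with a stated time of 48 h (on this read-out higher numbers stand for weaker inhibition and lower numbers for stronger inhibition), which is a limit of the assay and not a number. Compound 2 `COc1cc(-c2nnc3n2NC(c2ccco2)C(C(=O)c2ccccc2)S3)cc(OC)c1OC` gives 90900 nM in this assay.

Within the data shown here, compound 2 therefore holds the only number here; the other value is a limit. The step of an at least 1.1-fold lower number from compound 1 to compound 2 (0.04 log units; that floor lies within the scatter) rests on that limit of > 100000 nM in this assay, at which 1 of the 2 values shown sits, and says little. Compound 3 `COc1cc(-c2nnc3n2NC(c2ccco2)C(C(=O)c2cccc4ccccc24)S3)cc(OC)c1OC` differs from compound 2 by naphthalen-1-yl in place of phenyl on a carbonyl carbon. Among the measured compounds shown here, no measured step covers this change, so no shift beyond the scatter is expected: the step of a 1.5-fold lower number from compound 2 to compound 3 (0.18 log units; within the scatter) is an estimate. Compound 3 is expected to give 60000 nM, between 20000 nM and 150000 nM.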

Compound 3, half-maximal inhibitory concentration: 33900 nM
Compound 3: middle estimate off by 1.8-fold (0.25 log units), on the high side; measured number inside the range.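

In this assay, naphthalen-1-yl in place of phenyl on a carbonyl carbon gives a 2.7-fold lower number from compound 2 to compound 3 (0.43 log units; beyond the scatter), so the group on this carbonyl can shift the number beyond the scatter, though only modestly. Naphthalen-1-yl in place of 4-bromophenyl gives an at least 2.9-fold lower number from compound 1 to compound 3 (0.46 log units; beyond the scatter). That step is only a floor, since compound 1 stands at a limit of the assay and not at a number: the limit of > 100000 nM in this assay, at which 1 of the 3 values shown sits.

The compounds shown leave open whether naphthalen-2-yl or a saturated cyclohexyl group on this carbonyl carbon would give a similar shift. They also leave open whether the second aromatic ring itself accounts for the change.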